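Removing One Piperazinyl Group: An Expected Lipophilicity Shift

The source may report more compounds than this note shows. Statements on the series, on what has been measured and on what is new or still open speak of the compounds shown alone.

Of the compounds shown here, three sharing one fused core have been measured in a physicochemical assay for lipophilicity, read by HPLC, at pH 7.4; on this read-out lower numbers stand for lower lipophilicity and higher numbers for higher lipophilicity. Compound 1 `CN(C)CCCNc1c(C#N)c2nc3ccccc3n2c2c1sc1ccccc12` carries a dimethylaminopropylamino side chain and in this assay gives 3.44. Compound 2 `CN(C)CCCNc1ccc2c(c1)sc1cc(C#N)c3nc4ccccc4n3c12` places a chain of the same name elsewhere on the core and gives 2.91. Compound 3 `N#Cc1c(N2CCNCC2)c2sc3cc(N4CCNCC4)ccc3c2n2c1nc1ccccc12` carries two piperazin-1-yl groups and gives 1.89, the lowest of the three; compound 2 stands a gap above it that lies beyond the scatter, and compound 1 stands further above still.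

Compound 4 `N#Cc1c(N2CCNCC2)c2sc3ccccc3c2n2c1nc1ccccc12` is not yet measured. It differs from compound 3 in one place: hydrogen in place of piperazin-1-yl on an aromatic carbon. The piperazin-1-yl group is lost on an aromatic carbon of a six-membered aromatic ring of carbon only, within a fused or bridged system of five rings, and only a hydrogen remains there.

Among the measured compounds shown here, no measured pair shows this exact change. An upward move is expected because compound 3 gives 1.89 while compounds 1 and 2 with a single amine-bearing chain sit clearly higher. The step of a number 1.01 log units higher from compound 3 to compound 4 (beyond the scatter) is expected to be a rise beyond the scatter. Compound 4 is therefore expected to give about 2.9, within 2.3 to 3.5.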

Compound 4, distribution coefficient: 3.44
Estimate against measurement, compound 4: 0.54 log units below, within the range that was stated.
By their numbers in this assay, from the lowest: compound 3; then compound 2; then compounds 1 and 4 (each within the scatter of the next).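

The earlier compounds shown here offered no pair differing in one place, so the size of this exchange could not be read directly. On an aromatic carbon of a six-membered aromatic ring of carbon only, putting hydrogen in place of piperazin-1-yl gives, in this assay, a number 1.55 log units higher from compound 3 to compound 4 (beyond the scatter) and this is a large move for a single change on the shared core. The result also links compound 4 to compound 1, which differ by piperazin-1-yl in place of (3-(dimethylamino)propyl)amino on an aromatic carbon: this assay shows no change at the digits printed from compound 1 to compound 4 (within the scatter) so this pair cannot be told apart on this read-out, and nothing measured here explains why either step came out as it did.

Going by these compounds, it remains open where a smaller amine such as dimethylamino, or a carboxylic acid, would fall on the same aromatic carbon relative to compound 3 and compound 4. Among the compounds shown here, also open is whether taking away the other piperazin-1-yl group, the one kept in compound 4, would produce a step of similar size.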